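The compounds below may be only part of what the source reports. "The series", "measured", "known", "first", "only" and "open" are said of these compounds alone.

Series notes. Compound 1 `COCC(C(=O)N1CCN(c2cccc(C(F)(F)F)c2)CC1)N1C(=O)CCC1=O` gives 50% in a functional assay on the whole organism (strain Swiss) with Mus musculus as the target, in the maximal electroshock model, with a stated time of 1 h, at a dose of 100 mg/kg by the intraperitoneal route; on this read-out higher numbers stand for a stronger effect at the one dose given and lower numbers for a weaker effect. Compound 2 `CC(C(=O)N1CCN(c2ccc(F)cc2)CC1)N1C(=O)CCC1=O` gives 0% in this assay, and compound 3 `CCC(C(=O)N1CCN(c2cccc(C)c2)CC1)N1C(=O)CCC1=O` gives 0% in this assay. On these numbers compound 2 sits level with compound 3 at the digits shown, together the lowest of the three; compound 1 lies a step higher that is beyond the scatter, while compound 2 and compound 3 differ by nothing beyond the scatter.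

Compound 4 `CC(C(=O)N1CCN(c2cccc(Cl)c2)CC1)N1C(=O)CCC1=O` is not yet measured. Its change from compound 2 is 3-chlorophenyl in place of 4-fluorophenyl on an amine nitrogen in a ring. Within the data shown here, no measured pair shows this change alone, so the step is expected to be small and upward at most. For compound 4 the expected step is a number 20 percentage points higher from compound 2 to compound 4 (beyond the scatter) in this assay. Compound 4 is estimated at 20% in this assay, with a range from 0% to 50%.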

Compound 4, a percentage reported as activity, at one dose (the size of the read-out at that dose, not a potency): 50%
Compound 4: the middle estimate sits 30 percentage points below what was measured; low and high end bracket the measured number.
By their numbers in this assay, from the lowest: compounds 2 and 3 (each within the scatter of the next); then compounds 1 and 4 (each within the scatter of the next).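

In this assay, among these compounds, the step of a number 50 percentage points higher from compound 2 to compound 4 (beyond the scatter) is the first that can be read at one place. With the rest of the structure held constant, the aryl group on the amine nitrogen in a ring is enough on its own to move this read-out. No measurement at hand bears on the reason for this step.

The change swaps the halogen and its ring position together, so neither can be credited separately. From the compounds shown here alone, how a plain phenyl or a bromophenyl group would read on the same nitrogen remains open.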